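Ortho chloro on the benzylidene ring of the hydrazide core

This account rests on a few compounds, and the source may have more. Where it says the series, first, only, none or still open, it means among the compounds named here.

Compound 1 `Cc1ccc(C(=O)N/N=C/c2ccccc2)c(O)c1` is the parent of the set. For the measured compounds named here, in a functional assay (Mus musculus, strain BALB/C) for inhibition, read by MTT assay, with stated times of 24 h and 72 h (on this read-out lower numbers stand for stronger inhibition and higher numbers for weaker inhibition), compound 1 gives 53900 nM, the higher of the two numbers so far; the nearest neighbour is compound 2 `COc1cccc(/C=N/NC(=O)c2ccc(C)cc2O)c1`, which in this assay gives 20600 nM, so that a 2.6-fold lower number from compound 1 to compound 2 (0.42 log units; beyond the scatter). Compound 3 `Cc1ccc(C(=O)N/N=C/c2ccc(N(C)C)cc2)c(O)c1` is the third member; in this assay compound 3 reaches only a limit, > 100000 nM, because of the limit of > 100000 nM in this assay, at which 1 of the 3 values shown sits. From that limit follows an at least 1.8-fold higher number from compound 1 to compound 3 (0.26 log units; that floor lies within the scatter).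

Compound 4 `Cc1ccc(C(=O)N/N=C/c2ccccc2Cl)c(O)c1` has not yet been measured. It differs from compound 1 by chloro in place of hydrogen on an aromatic carbon. Neither measured step is the same change: the methoxy step was modest and beyond the scatter, the dimethylamino step sits at a floor within the scatter, and the two run in opposite directions. A chloro on the same ring is therefore expected to move the number little, with no step beyond the scatter in either direction; the estimate for compound 4 is 45000 nM, within 15000 nM to 150000 nM, meaning a 1.2-fold lower number from compound 1 to compound 4 (0.08 log units; within the scatter).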

Compound 4, half-maximal inhibitory concentration: 19200 nM
Compound 4: middle estimate off by 2.3-fold (0.37 log units), on the high side, within the range that was stated.
By their numbers in this assay, from the lowest: compounds 4 and 2 (each within the scatter of the next); then compound 1. At a limit, above all of these: compound 3.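

In this assay, a 2.8-fold lower number from compound 1 to compound 4 (0.45 log units; beyond the scatter), so one chlorine atom on an aromatic carbon, ortho to a large group, is enough to move the number beyond the scatter, and methoxy in compound 2 is no longer the only substituent shown to lower it relative to compound 1. Compound 3 goes against any general lowering by substituents on this ring, and its value is a limit: the limit of > 100000 nM in this assay, at which 1 of the 4 values shown sits. No measurement shown bears on why the chloro step has this direction or size.

Still open, from the compounds shown here alone, is whether chloro elsewhere on the ring gives a similar step, and whether bromo or nitro in the same place would follow it. A carboxylic acid or a primary amine on this ring also remains an open case.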